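The compounds below may be only part of what the source reports. "The series", "measured", "known", "first", "only" and "open" are said of these compounds alone.

Compound 2, `COc1ccc([C@@H]2CC(=O)c3c(O)cc(OCc4cn(Cc5ccc(C)cc5)nn4)cc3O2)cc1O`, gives 16800 nM in a functional assay on RAW264.7 cells (Mus musculus) for inhibition, read by Griess assay, with stated times of 2 h and 24 h (a higher number here means a weaker inhibitor, a lower number a stronger inhibitor), the higher of the two numbers recorded so far. Its nearest neighbour is compound 1, `COc1ccc([C@@H]2CC(=O)c3c(O)cc(OCc4cn(C5CCCC5)nn4)cc3O2)cc1O`, which in this assay gives 10500 nM; the step between them, a 1.6-fold higher number from compound 1 to compound 2 (0.20 log units; within the scatter), stays within the usual scatter. Compound 3, `COc1ccc([C@@H]2CC(=O)c3c(O)cc(OCc4cn(Cc5cccc(C)c5)nn4)cc3O2)cc1O`, differs from compound 2 by 3-methylphenyl in place of 4-methylphenyl on a saturated chain carbon bound to an aromatic nitrogen. Among the measured compounds shown here, only one measured step bears on this part of the molecule, and it exchanges cyclopentyl for 4-methylbenzyl on the aromatic nitrogen, a change that left the number essentially where it was; no measured step moves the methyl around the benzyl ring, so there is nothing to suggest a direction. Compound 3 is therefore expected to sit close to compound 2, with a step of a 1.1-fold lower number from compound 2 to compound 3 (0.02 log units; within the scatter) in this assay. The estimate for compound 3 is 16000 nM, with a range from 7000 nM to 36000 nM.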

Compound 3, half-maximal inhibitory concentration: 17400 nM
Beside the measured number, compound 3's estimate is 1.1-fold (0.04 log units) below it, within the range that was stated.
By their numbers in this assay, from the lowest: compounds 1, 2 and 3 (each within the scatter of the next).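

Moving the methyl from 4-methylphenyl to 3-methylphenyl, on a saturated chain carbon bound to an aromatic nitrogen, gives a 1.0-fold higher number from compound 2 to compound 3 (0.02 log units; within the scatter) in this assay, so the placing of the methyl on the ring has no readable effect on the number here. Set against the cyclopentyl group, the second methylbenzyl gives a 1.7-fold higher number from compound 1 to compound 3 (0.22 log units; within the scatter), so neither methylbenzyl group separates from cyclopentyl on the aromatic nitrogen, and the three compounds cannot be ranked. No measurement is available that would account for this flat result.

Going by these compounds, whether an amine or a carboxylic acid in place of the methyl, or a longer chain on the aromatic nitrogen, would move the number beyond the scatter remains open. So does the effect of any change to the shared core, which is the same in all three compounds.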